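A few compounds are considered here, and "the series" means these few. Any claim that something is new, unique, unknown or untested is made for them only; others in the source may bear on it.

Compound 1 `CCOc1ccc(C2(c3ccc(O)cc3)C(=O)Nc3c2ccc(F)c3F)cc1`: 24 nM
Compound 2 `CCCOc1ccc(C2(c3ccc(O)cc3)C(=O)Nc3c2ccc(F)c3F)cc1`: > 1000 nM

In a functional assay on PC-3 cells (Homo sapiens) for cytotoxicity, read by WST assay, with a stated time of 72 h (a higher number here means a weaker inhibitor, a lower number a stronger inhibitor), compound 1 gives 24 nM, the only number shown. For compound 2 the assay reports only a limit, > 1000 nM (the limit of > 1000 nM in this assay, at which 1 of the 2 values shown sits). Within the data shown here, the single measured step is an at least 41-fold higher number from compound 1 to compound 2 (1.61 log units; beyond the scatter), a large loss from a small change. Compound 3 `CCCC1(c2ccc(O)cc2)C(=O)Nc2c1ccc(F)c2F` differs from compound 1 in a different way: propyl in place of 4-ethoxyphenyl on a saturated ring carbon. Among the measured compounds shown here, no measured step covers the removal of the aromatic group, yet the large effect of an at least 41-fold higher number from compound 1 to compound 2 (1.61 log units; beyond the scatter) in this assay leads to an expected large increase, a 130-fold higher number from compound 1 to compound 3 (2.10 log units; beyond the scatter). Compound 3 is therefore expected to give about 3000 nM, between 300 nM and 30000 nM.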

Compound 3, half-maximal inhibitory concentration: > 1000 nM
Compound 3 ended at the assay's limit; the forecaster's own chance of this, stated with the estimate: 60%; the middle value is on the limit's open side.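

In this assay compound 3 gives > 1000 nM, which is a limit of the assay and not a number. On the saturated ring carbon, propyl in place of 4-ethoxyphenyl gives an at least 41-fold higher number from compound 1 to compound 3 (1.61 log units; beyond the scatter), so the loss is no longer tied to lengthening the ethoxy chain alone, since here the whole aromatic group is replaced. The true size of this step remains unknown, and the limit now holds most of the series: the limit of > 1000 nM in this assay, at which 2 of the 3 values shown sit.

Going by these compounds, whether a 4-methoxyphenyl or a 4-aminophenyl at this carbon would keep the value of compound 1 stays open.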